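The source may report more compounds than this note shows. Statements on the series, on what has been measured and on what is new or still open speak of the compounds shown alone.

Measured compounds in a functional assay on BCG823 cells (Homo sapiens) for inhibition, read by MTT assay, with a stated time of 72 h; a lower number here means a stronger inhibitor, a higher number a weaker inhibitor:
- compound 1, `CNc1nc(C)c(C(=O)N/N=C/c2cccc(C(F)(F)F)c2)s1`, which in this assay gives > 100 ug/mL, a limit of the assay and not a number.
- compound 2, `CNc1nc(C(F)(F)F)c(C(=O)N/N=C/c2cccc(C(F)(F)F)c2)s1`, which in this assay gives > 100 ug/mL, likewise a limit and not a number.

Compound 2 therefore stands at the limit of this assay with no number of its own. Among the compounds with values here, the one measured step, a step that the two limits leave unreadable from compound 1 to compound 2, cannot be read because the limit of > 100 ug/mL in this assay, at which 2 of the 2 values shown sit, sets both ends at the same limit.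

Compound 3, `CN(C(=O)NC(=O)c1ccccc1F)c1nc(C(F)(F)F)c(C(=O)N/N=C/c2cccc(C(F)(F)F)c2)s1`, differs from compound 2 by ((2-fluorophenyl)carbonyl)carbamoyl in place of hydrogen on a nitrogen on an aromatic ring. Within the data shown here, no measured step bears on this change; the single step recorded, from compound 1 to compound 2, concerns a different position and is unreadable in any case. With nothing read beyond the limit for compound 2, no direction can be drawn for this assay. Compound 3 is estimated at 90 ug/mL, with a range from 20 ug/mL to 400 ug/mL, the step from compound 2 being an at least 1.1-fold lower number from compound 2 to compound 3 (0.04 log units; that floor lies within the scatter) and most likely ending again at the limit.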

Compound 3, half-maximal inhibitory concentration: 16.3 ug/mL
Compound 3: middle estimate off by 5.5-fold (0.74 log units), on the high side; measured number outside the range, below it.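

In this assay, within the data shown here, ((2-fluorophenyl)carbonyl)carbamoyl in place of hydrogen on a nitrogen on an aromatic ring gives an at least 6.1-fold lower number from compound 2 to compound 3 (0.78 log units; beyond the scatter), the first step that can be read. This nitrogen is therefore a position where a change moves the number beyond the scatter, whereas the earlier step, trifluoromethyl in place of methyl on an aromatic carbon, cannot be read. The size given for the new step is only a floor, because compound 2 sits at a limit of the assay and not at a number: the limit of > 100 ug/mL in this assay, at which 2 of the 3 values shown sit.

The group entered as a whole, so the compounds shown do not separate the contribution of its parts, and it remains open whether a simple acetyl group, a plain benzoyl urea without the fluorine, or a longer alkyl chain on this nitrogen would give a comparable step. Going by these compounds, it also remains open whether the same ((2-fluorophenyl)carbonyl)carbamoyl group would lower the number in the same way on compound 1, which carries methyl where compound 2 carries trifluoromethyl.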